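The source may report more compounds than this note shows. Statements on the series, on what has been measured and on what is new or still open speak of the compounds shown alone.

Working notes on the stereoisomer series. In an ADME assay on the whole organism (Mus musculus, strain C57BL/6) for pharmacokinetics, read by HPLC, with a stated time of 6 h, at a dose of 25 mg/kg by the oral route (a lower number here means less compound in the circulation, a higher number more compound in the circulation at the dose given), compound 3 `O=C(N[C@H](CO)C(=O)O)[C@@H]1C[C@@H](O)CN1` gives 640 nM, the lowest of the three measured, against compound 1 `O=C(O)[C@H](CO)NC(=O)[C@H]1C[C@H](O)CN1` at 4010 nM and compound 2 `O=C(O)[C@@H](CO)NC(=O)[C@H]1C[C@@H](O)CN1` at 24000 nM.

Compound 4 `O=C(O)[C@H](CO)NC(=O)[C@@H]1C[C@@H](O)CN1` has the same atoms and bonds as compound 3: the two compounds have the same atoms and bonds and differ only in configuration as drawn: 1 of 3 stereo elements differ; a stereocentre at a saturated chain carbon is drawn R in compound 3 and S in compound 4, a stereocentre at a saturated chain carbon being drawn R in compound 3 and S in compound 4.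

Among the measured compounds shown here, no measured step inverts that chain stereocentre alone. The nearest is a 6.0-fold higher number from compound 1 to compound 2 (0.78 log units; beyond the scatter), where the chain centre moves from S to R together with a ring centre. Read on its own, that step would suggest a lower number on going back to S. Against this, a 6.3-fold lower number from compound 1 to compound 3 (0.80 log units; beyond the scatter) inverts every centre and shows that compound 1, with the chain centre drawn S, stands higher. The largest change, a 38-fold lower number from compound 2 to compound 3 (1.57 log units; beyond the scatter), comes from a single ring centre, and compound 4 keeps that centre as drawn in compound 3.

The two indications on the chain centre conflict, so no clear direction is expected in this assay, and a step of modest size either way remains possible. The expected result is a 1.1-fold lower number from compound 3 to compound 4 (0.03 log units; within the scatter), which is not beyond the scatter. Compound 4 is estimated at 600 nM, with an expected range from 100 nM to 3500 nM.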

Compound 4, maximal plasma concentration: 520 nM
Beside the measured number, compound 4's estimate is 1.2-fold (0.06 log units) above it; measured number inside the range.
By their numbers in this assay, from the lowest: compounds 4 and 3 (each within the scatter of the next); then compound 1; then compound 2.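

In this assay, among the compounds shown here, the first step to invert the chain stereocentre alone is a 1.2-fold lower number from compound 3 to compound 4 (0.09 log units; within the scatter), so with the ring centres as drawn in this pair, the configuration at that chain carbon does not separate the two numbers. The other new steps, a 46-fold lower number from compound 2 to compound 4 (1.66 log units; beyond the scatter) and a 7.7-fold lower number from compound 1 to compound 4 (0.89 log units; beyond the scatter), both change ring centres: the first inverts one ring centre together with the chain centre, and the second inverts two ring centres while the chain centre stays drawn S. Across the four compounds, every step beyond the scatter includes at least one ring centre, and the only step that leaves both ring centres untouched lies within it, with no listed pair going against this.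

Still open, as far as these compounds go, is whether inverting the chain centre alone would be as small a step with the ring centres as drawn in compound 1 or compound 2, where the numbers are higher. Also open, from the compounds shown here alone, is how the maximal plasma concentration would respond to a change in the atoms themselves, such as a methyl ester in place of the carboxylic acid or an amine in place of the ring hydroxyl group.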